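Methyl in Place of Methoxy: Expecting a Value for Compound 4

This account rests on a few compounds, and the source may have more. Where it says the series, first, only, none or still open, it means among the compounds named here.

Compound 1 `Cc1ccc(-c2cs/c(=N/NC(=O)CSc3nnnn3-c3ccccc3)n2-c2ccccc2)cc1`: 14.7 ug/mL
Compound 2 `COc1ccc(-c2cs/c(=N/NC(=O)CSc3nnnn3-c3ccccc3)n2-c2ccccc2)cc1`: "not determined" (no result reported)
Compound 3 `COc1ccc(-c2cs/c(=N/NC(=O)CSc3nncn3C)n2-c2ccccc2)cc1`: "not determined" (no result reported)

All numbers come from a functional assay on C6 cells (Rattus norvegicus) for cytotoxicity, read by MTT assay, with a stated time of 24 h; a lower number here means a stronger inhibitor, a higher number a weaker inhibitor. Compound 1 gives 14.7 ug/mL in this assay. Compound 2 gives "not determined" (no result reported), and compound 3 gives "not determined" (no result reported), so compound 3 has no number to stand on, and one further compound lacks one as well. Compound 4 `Cc1ccc(-c2cs/c(=N/NC(=O)CSc3nncn3C)n2-c2ccccc2)cc1` has not been measured. It differs from compound 3 by methyl in place of methoxy on an aromatic carbon. Within the data shown here, no step between measured compounds exists, so the size of this change cannot be read from the data; a shift within the usual scatter, with no clear direction, is expected. Among the measured compounds shown here, the only number available is that of compound 1 in this assay, and the expectation leans on it. Compound 4 is estimated at 15 ug/mL, within 5 ug/mL to 45 ug/mL.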

Compound 4, half-maximal inhibitory concentration: 56 ug/mL
The estimate for compound 4 lay 3.7-fold (0.57 log units) below the measured number; the measured number lies above the stated range.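

With the 4-methylphenyl group held constant, this assay now shows that the group on the sulfur matters, giving a 3.8-fold higher number from compound 1 to compound 4 (0.58 log units; beyond the scatter) when 4-methyl-4H-1,2,4-triazol-3-yl replaces 1-phenyl-1H-tetrazol-5-yl. This is one step between two compounds, so it sets no general rule. No evidence is available to explain it.

The effect of 4-methoxyphenyl to 4-methylphenyl cannot be read, as compound 3 has no number. Also open, as far as these compounds go, is how an amine or a carboxylic acid at that aromatic carbon, or a longer chain on the sulfur, would behave.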